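The compounds below may be only part of what the source reports. "The series", "measured", "known", "first", "only" and "open" are said of these compounds alone.

Working notes on the series. Compound 1 `COc1cc(CNC(=O)[C@H]2[C@@H](C=C(C)C)C2(C)C)ccc1O` gives 200 nM in a functional assay on HEK293 cells with transient receptor potential cation channel subfamily V member 1 (Homo sapiens) as the target; a higher number here means that more compound is needed for the effect, a lower number that less compound is needed. Compound 2 `C=CCCCCCCCCC(=O)NCc1ccc(O)c(OC)c1` gives 2 nM in this assay, and compound 3 `CCCCCC[C@@H](O)CCCCCCCCCCC(=O)NCc1ccc(O)c(OC)c1` gives 5.01 nM. On these three numbers compound 3 stands second highest, nearer to compound 2 than to compound 1, whose number is far higher. Going by the values given here, the one step measured along the chain end is a 2.5-fold higher number from compound 2 to compound 3 (0.40 log units; beyond the scatter); it shows that building out the chain end with a hydroxyl-bearing group costs a modest amount. Compound 4 `CCCCCCCC[C@H]1C[C@H]1CCCCCCCCCCC(=O)NCc1ccc(O)c(OC)c1` carries the next change: 2-octylcyclopropyl in place of 1-hydroxyheptyl on a saturated chain carbon, ten or more bonds along the chain from a carbonyl carbon. No measured step exchanges a hydroxyl-bearing chain for a ring-bearing one, so the direction of this change is not shown by the data; the only bearing step is the modest one from compound 2 to compound 3, and the change here again reshapes the chain end rather than the core. The expected step is therefore small, a 1.3-fold lower number from compound 3 to compound 4 (0.10 log units; within the scatter), within or near the scatter. Compound 4 is estimated at 4 nM, with a range from 1 nM to 20 nM.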

Compound 4, half-maximal effective concentration: 79.4 nM
For compound 4 the middle estimate is 20-fold (1.30 log units) below the measured one; measured number above the stated range.
By their numbers in this assay, from the lowest: compound 2; then compound 3; then compound 4; then compound 1.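

On a saturated chain carbon, 2-octylcyclopropyl in place of 1-hydroxyheptyl gives a 16-fold higher number from compound 3 to compound 4 (1.20 log units; beyond the scatter) in this assay and so marks the chain end as a sensitive part of the series. With the shared core unchanged, a change at the chain end alone moves the number much further than the earlier 2.5-fold higher number from compound 2 to compound 3 (0.40 log units; beyond the scatter) did. The change removes the hydroxyl and brings in the three-membered ring and a larger group together, and no supporting measurement accounts for the step.

Open, as far as these compounds go, is which of these parts carries the step. A straight alkyl chain in place of the 2-octylcyclopropyl group, or a hydroxyl group kept on the ring-bearing chain, would separate the ring from the hydroxyl.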